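Reading a fluorine swap on the benzyl side chain

A few compounds are considered here, and "the series" means these few. Any claim that something is new, unique, unknown or untested is made for them only; others in the source may bear on it.

Values measured in a functional assay on HL-60 cells (Homo sapiens) for antiproliferative activity, with a stated time of 72 h; on this read-out lower numbers stand for stronger inhibition and higher numbers for weaker inhibition:
Compound 1 `OC[C@H]1O[C@@H](n2cnc3c(NCc4cccc(F)c4)ncnc32)[C@H](O)[C@@H]1O`: 920 nM
Compound 2 `OC[C@H]1O[C@@H](n2cnc3c(NCc4c(F)ccc(F)c4F)ncnc32)[C@H](O)[C@@H]1O`: 13000 nM

Compound 2, at 13000 nM, has the higher of the two numbers, so it is the weaker inhibitor of the pair. Among the measured compounds shown here, its only neighbour is compound 1, and the gap is a 14-fold higher number from compound 1 to compound 2 (1.15 log units; beyond the scatter).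

Compound 3 `OC[C@H]1O[C@@H](n2cnc3c(NCc4ccc(F)c(Cl)c4)ncnc32)[C@H](O)[C@@H]1O` has not been measured yet. It keeps the shared core and changes one group of compound 2, on a saturated chain carbon bound to a nitrogen on an aromatic ring: 3-chloro-4-fluorophenyl in place of 2,3,6-trifluorophenyl (3-chloro-4-fluorophenyl in place of 2,3,6-trifluorophenyl on a saturated chain carbon bound to a nitrogen on an aromatic ring).

For the measured compounds named here, only one measured step bears on this change, the large one between compound 1 and compound 2, and no measured compound contains chlorine, so the evidence is thin. Still, the new group resembles the 3-fluorophenyl of compound 1, at 920 nM, more than the group it replaces. A large move to a lower number is therefore expected in this assay. The expected change is an 8.7-fold lower number from compound 2 to compound 3 (0.94 log units; beyond the scatter). For compound 3 the estimate is 1500 nM, with an expected range of 350 nM to 7000 nM.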

Compound 3, half-maximal inhibitory concentration: 3500 nM
Compound 3: the middle estimate sits 2.3-fold (0.37 log units) below what was measured, and the stated range covers the measured number.
By their numbers in this assay, from the lowest: compound 1; then compound 3; then compound 2.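

In this assay, putting 3-chloro-4-fluorophenyl where compound 2 carries 2,3,6-trifluorophenyl, on a saturated chain carbon bound to a nitrogen on an aromatic ring, wins back part of the lost activity (a 3.7-fold lower number from compound 2 to compound 3 (0.57 log units; beyond the scatter)), but not all of it, as the same group in place of the 3-fluorophenyl of compound 1 still costs activity (a 3.8-fold higher number from compound 1 to compound 3 (0.58 log units; beyond the scatter)). Compound 3 therefore sits between the two earlier compounds, so this position gives graded results rather than just a good outcome and a bad one, and a ring carrying chlorine keeps measurable activity. Nothing measured alongside these numbers says why the three rings rank in this order.

Each step changes more than one ring substituent at once, so the shares of the added chlorine, of the fluorine placement and of the fluorines that leave cannot be separated with these compounds. An unsubstituted phenyl ring, or a ring bearing a methoxy group instead of a halogen, would show whether any halogen is needed at this position at all.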